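A Ring Amine Replaces a Chain Amine on a Shared Core

The source may report more compounds than this note shows. Statements on the series, on what has been measured and on what is new or still open speak of the compounds shown alone.

In a functional assay on K562 cells (Homo sapiens) for inhibition, read by MTT assay and WST assay, with a stated time of 72 h, tested at 10 uM (a lower number here means less inhibition of growth, a higher number more inhibition of growth at the concentration tested), compound 1 `CCN1CCN(c2cc(Nc3ccc4sc(C(=O)Nc5c(C)cccc5Cl)cc4c3)nc(C)n2)CC1` gives 33.9%. Compound 2 `CCN(CC)CCCOc1cc2ncnc(Nc3ccc4sc(C(=O)Nc5c(C)cccc5Cl)cc4c3)c2cc1OC` gives 72.5% in this assay, the higher of the two numbers, and its gap to compound 1 lies beyond the scatter. Compound 3 `COc1cc2c(Nc3ccc4sc(C(=O)Nc5c(C)cccc5Cl)cc4c3)ncnc2cc1OCCCN1CCCCC1C` differs from compound 2 in one place: 2-methylpiperidin-1-yl in place of diethylamino on a saturated chain carbon, three bonds along the chain from an oxygen on an aromatic ring. Within the data shown here, no measured pair differing in one place exists here, so the size of this step is not known from the data; the expected step is small, a number 2.5 percentage points lower from compound 2 to compound 3 (within the scatter), within the scatter. Compound 3 is accordingly estimated at about 70%, with a range from 50% to 88%.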

Compound 3, percent growth inhibition at one concentration: 84.2%
The estimate for compound 3 lay 14.2 percentage points below the measured number; the range from low to high includes it.
By their numbers in this assay, from the lowest: compound 1; then compound 2; then compound 3.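

In this assay, 2-methylpiperidin-1-yl in place of diethylamino gives a change of a number 11.7 percentage points higher from compound 2 to compound 3 (beyond the scatter) at the end of the 3-carbon-free propyl chain.

That first sentence was faulty, so here is the corrected passage in full.

In this assay, 2-methylpiperidin-1-yl in place of diethylamino, on the 3-(diethylamino)propyl chain, gives a change of a number 11.7 percentage points higher from compound 2 to compound 3 (beyond the scatter) on the shared core. This position therefore accepts a six-membered ring amine in place of an open-chain amine without any loss of growth inhibition. No measurement shown accounts for this step.

On these data alone, it remains open whether the ring or its methyl group carries the step, which piperidin-1-yl without the methyl group or morpholin-4-yl could address. As far as these compounds go, a longer chain ahead of the amine is equally open.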